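The source may report more compounds than this note shows. Statements on the series, on what has been measured and on what is new or still open speak of the compounds shown alone.

Of the compounds shown here, two with a shared core have been measured in an assay on CHO-K1 cells for displacement of a labelled ligand from Neuronal acetylcholine receptor; alpha4/beta2 (Homo sapiens), read by scintillation counting; on this read-out higher numbers stand for weaker inhibition and lower numbers for stronger inhibition. Compound 1 `Cc1ccc(OC[C@@H]2C[C@H]3C[C@H]3N2C)cn1` gives 20 nM, the lowest of the two numbers recorded. Compound 2 `Cc1ncccc1OC[C@@H]1C[C@H]2C[C@H]2N1C` differs from it in how the aromatic ring is substituted, and in this assay compound 2 gives 231 nM, a higher number that lies beyond the usual scatter of such measurements.

Compound 3 `CN1[C@H](COc2ccc(F)nc2)C[C@H]2C[C@H]21` has not yet been measured. It differs from compound 1 in one place: fluoro in place of methyl on an aromatic carbon. Among the measured compounds shown here, no measured pair shows this exact change, so there is no directly comparable step to lean on. A small group is swapped for another small group of the same size, and such swaps at this position often leave binding close to where it was.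

Compound 3 is therefore expected to give about 28 nM, within a range of 8 nM to 90 nM, which amounts to an estimated step of a 1.4-fold higher number from compound 1 to compound 3 (0.15 log units; within the scatter), within the scatter or only slightly beyond it.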

Compound 3, inhibition constant: 1.1 nM
Compound 3: middle estimate off by 25-fold (1.41 log units), on the high side; measured number below the stated range.
By their numbers in this assay, from the lowest: compound 3; then compound 1; then compound 2.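

In this assay, fluoro in place of methyl gives an 18-fold lower number from compound 1 to compound 3 (1.26 log units; beyond the scatter), so this place next to the ring nitrogen is far from indifferent to which small group it carries. The two groups match in heavy-atom count and neither has a hydrogen-bond donor or acceptor, so these simple counts do not predict the size of this step. Nothing measured here explains why the number falls so far.

Among the compounds shown here, with only two groups compared at this place, it remains open whether the lower number comes from adding fluoro or from removing methyl. A chloro, methoxy or amino group here could help separate those possibilities, while the same swap on the ring of compound 2 would test whether the step carries over.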